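Acyl variation on the guanidine nitrogen: series notes

The compounds below may be only part of what the source reports. "The series", "measured", "known", "first", "only" and "open" are said of these compounds alone.

Compound 1, `CCC(C)(C)N/C(=N\O)Nc1cccnc1`: in a functional assay on the whole organism (blood, strain Wistar-Okamoto) with Rattus norvegicus as the target, with a stated time of 5 days (on this read-out higher numbers stand for an effect only at larger amounts of compound and lower numbers for an effect already at smaller amounts), compound 1 gives > 20 mg/kg, which is a limit of the assay.
Compound 2, `CCOC(=O)/N=C(/Nc1cccnc1)NC(C)(C)CC`: in this assay compound 2 gives 20 mg/kg.
Compound 3, `CCC(C)(C)N/C(=N\C=O)Nc1cccnc1`: in this assay compound 3 gives > 20 mg/kg, which is a limit of the assay.

Within the data shown here, compound 3 therefore stands only at a limit, and so does compound 1; compound 2 is the sole compound with a number. The step from compound 2 to compound 3, hydrogen in place of ethoxy on a carbonyl carbon, reads a number no lower from compound 2 to compound 3 (the limit leaves the size open). The step that the two limits leave unreadable from compound 1 to compound 3 cannot be sized. Two of three values sit at the same limit (the limit of > 20 mg/kg in this assay, at which 2 of the 3 values shown sit).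

Compound 4, `CCC(C)(C)N/C(=N\C(=O)C(F)(F)F)Nc1cccnc1`, differs from compound 3 by trifluoromethyl in place of hydrogen on a carbonyl carbon. Among the measured compounds shown here, the only measured step at the same carbonyl carbon is a number no lower from compound 2 to compound 3 (the limit leaves the size open), which gives no readable size. For the measured compounds named here, no measured step involves trifluoromethyl. The expected step is therefore a number no higher from compound 3 to compound 4 (the limit leaves the size open), with a limit again the likelier outcome. For compound 4 the expected minimum effective dose is 20 mg/kg, with a range from 10 mg/kg to 40 mg/kg.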

Compound 4, minimum effective dose: > 50 mg/kg
Compound 4: no number, only a limit; the forecaster's own chance of this, stated with the estimate: 60%; middle value at least 2.5-fold (0.39 log units) from the limit.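

In this assay the carbonyl carbon now gives its first step with a readable size, and it lies beyond the scatter: an at least 2.5-fold higher number from compound 2 to compound 4 (0.39 log units; beyond the scatter). Compound 4 gives > 50 mg/kg, which is a limit of the assay and not a number, and it stands alone at this limit: the limit of > 50 mg/kg in this assay, at which 1 of the 4 values shown sits. The steps to compound 4 from compound 3 and from compound 1 cannot be read, as both ends of each are limits.

Ethoxy remains the only group on this carbonyl carbon with a number, so how far the read-out moves with the group there stays open. Among these compounds, whether a methyl, a longer chain or an amine on the same carbonyl carbon would give a number, and whether that number would lie on either side of the one for compound 2, also stays open.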